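Swapping a chlorinated benzyl amide for a hexyl amide

A few compounds are considered here, and "the series" means these few. Any claim that something is new, unique, unknown or untested is made for them only; others in the source may bear on it.

Measured so far:
Compound 1 `Cc1ccc(CNC(=O)CN2C(=O)/C(=C/c3ccc(-c4ccc(Cl)cc4)o3)SC2=S)cc1` gives 45000 nM in a functional assay on K562 cells (Homo sapiens) for cytotoxicity, read by MTT assay, with a stated time of 72 h; a higher number here means a weaker inhibitor, a lower number a stronger inhibitor.
Compound 2 `O=C(CN1C(=O)/C(=C/c2ccc(-c3ccc(Cl)cc3)o2)SC1=S)NCc1ccc(Br)cc1` gives 68000 nM in this assay.
Compound 3 `O=C(CN1C(=O)/C(=C/c2ccc(-c3ccc(Cl)cc3)o2)SC1=S)NCc1ccccc1Cl` gives 64000 nM in this assay.

All three compounds share the same core and differ only in the group carried on the saturated chain carbon bound to the amide-type nitrogen. Compound 3 sits among them with nothing to set it apart: its number lies a 1.1-fold lower number from compound 2 to compound 3 (0.03 log units; within the scatter) and a 1.4-fold higher number from compound 1 to compound 3 (0.15 log units; within the scatter), both within the scatter, so the three cannot be told apart on these measurements.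

Compound 4 `CCCCCCNC(=O)CN1C(=O)/C(=C/c2ccc(-c3ccc(Cl)cc3)o2)SC1=S` takes the change (pentyl in place of 2-chlorophenyl on a saturated chain carbon bound to an amide-type nitrogen). Within the data shown here, every measured step so far exchanged one substituted phenyl for another: a 1.5-fold higher number from compound 1 to compound 2 (0.18 log units; within the scatter), a 1.4-fold higher number from compound 1 to compound 3 (0.15 log units; within the scatter) and a 1.1-fold lower number from compound 2 to compound 3 (0.03 log units; within the scatter), none beyond the scatter. Among the measured compounds shown here, no measured step replaces the aromatic ring with a chain, so nothing bears directly on this change, and the flat pattern of the measured steps is the only guide. The expectation for this assay is therefore no step beyond the scatter, with a wide range to reflect the missing evidence. For compound 4 the estimated value in this assay is 60000 nM, with a range from 20000 nM to 180000 nM. This estimate corresponds to a step of a 1.1-fold lower number from compound 3 to compound 4 (0.03 log units; within the scatter), which is expected to stay within the scatter.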

Compound 4, half-maximal inhibitory concentration: 50000 nM
The estimate for compound 4 lay 1.2-fold (0.08 log units) above the measured number, within the range that was stated.
By their numbers in this assay, from the lowest: compounds 1, 4, 3 and 2 (each within the scatter of the next).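

Compound 4 removes the aromatic ring at this place altogether, putting a pentyl on the saturated chain carbon bound to an amide-type nitrogen, and in this assay all three new steps stay within the scatter (a 1.3-fold lower number from compound 3 to compound 4 (0.11 log units; within the scatter)) (a 1.4-fold lower number from compound 2 to compound 4 (0.13 log units; within the scatter)) (a 1.1-fold higher number from compound 1 to compound 4 (0.05 log units; within the scatter)). The earlier compounds only exchanged one substituted phenyl for another, whereas these steps show that, among these four compounds, an open chain cannot be told apart from a ring at this place. No measurement shown here offers an explanation for this flat result.

The compounds shown leave open whether any group at this place can move the number beyond the scatter. A chain carrying an amine or a carboxylic acid, or a longer chain, would test this.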